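A few compounds are considered here, and "the series" means these few. Any claim that something is new, unique, unknown or untested is made for them only; others in the source may bear on it.

Measured compounds:
compound 1, `CCCCOC(=O)NS(=O)(=O)c1ccc(CCC)cc1-c1ccc(Cn2c(C3CCCCC3)nc3ccccc32)cc1`: 130 nM
compound 2, `CCCCOC(=O)NS(=O)(=O)c1ccc(CCC)cc1-c1ccc(Cn2c(C3CCC3)nc3ccccc32)cc1`: 12 nM

Within the data shown here, in an assay on membranes from HEK293 cells for displacement of a labelled ligand from Type-2 angiotensin II receptor (Homo sapiens), read by radioligand binding (a lower number here means a stronger inhibitor, a higher number a weaker inhibitor), compound 1 gives 130 nM, the higher of the two numbers measured so far, and compound 2 gives 12 nM. Among the measured compounds shown here, the single measured step, an 11-fold lower number from compound 1 to compound 2 (1.03 log units; beyond the scatter), comes from putting cyclobutyl in place of cyclohexyl on an aromatic carbon, so the smaller ring gave the stronger inhibitor.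

Compound 3, `CCCCOC(=O)NS(=O)(=O)c1ccc(CCC)cc1-c1ccc(Cn2c(CCC)nc3ccccc32)cc1`, is not yet measured in this assay. It differs from compound 1 by propyl in place of cyclohexyl on an aromatic carbon. For the measured compounds named here, the only step that bears on this change is an 11-fold lower number from compound 1 to compound 2 (1.03 log units; beyond the scatter), where a smaller group at the same aromatic carbon lowered the number by a large margin. Propyl is also smaller than cyclohexyl, though it is a chain rather than a ring, and no open chain has been measured at this carbon, so the direction is expected to be the same while the size is less certain.

For compound 3 the expected value in this assay is 20 nM, within a range from 5 nM to 80 nM. The expected step is a 6.5-fold lower number from compound 1 to compound 3 (0.81 log units; beyond the scatter).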

Compound 3, inhibition constant: 14 nM
The estimate for compound 3 lay 1.4-fold (0.15 log units) above the measured number, and the stated range covers the measured number.
By their numbers in this assay, from the lowest: compounds 2 and 3 (each within the scatter of the next); then compound 1.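

In this assay, the open chain does about as well as the small ring at this carbon between two ring nitrogen atoms. Propyl gives a 9.3-fold lower number from compound 1 to compound 3 (0.97 log units; beyond the scatter), and a 1.2-fold higher number from compound 2 to compound 3 (0.07 log units; within the scatter) leaves compound 2 and compound 3 within the scatter of each other, so among these three compounds a ring at this place is not needed for the lower number, and only the cyclohexyl of compound 1, with 6 heavy atoms against the 3 of propyl, stands apart. No measurement shown explains why compound 1 stands apart from the other two.

The three groups leave open how far this holds for other groups at the same carbon: a shorter chain such as ethyl, a longer chain such as pentyl, a branched group such as isopropyl, or cyclopentyl, the ring size that would show where along the series from cyclobutyl to cyclohexyl the number begins to rise. As far as these compounds go, since all three compounds share the rest of the core, it also remains open whether propyl and cyclobutyl would stay within the scatter of each other if another part of the core were changed.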